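Moving from a 3,5-Dimethylphenyl to a 4-Ethylphenyl Thioether

A few compounds are considered here, and "the series" means these few. Any claim that something is new, unique, unknown or untested is made for them only; others in the source may bear on it.

Measured compounds:
compound 1 `Nc1ccccc1NC(=O)c1ccc(CSc2ccc(Br)cc2)cc1`: 4.35%
compound 2 `CC(C)(C)c1ccc(SCc2ccc(C(=O)Nc3ccccc3N)cc2)cc1`: 2.13%
compound 3 `Cc1cc(C)cc(SCc2ccc(C(=O)Nc3ccccc3N)cc2)c1`: 48.5%

Of the compounds shown here, three sharing one core have been tested in a functional assay on A-375 cells (Homo sapiens) for inhibition, read by CCK-8 assay, with a stated time of 72 h, tested at 2 uM; on this read-out lower numbers stand for less inhibition of growth and higher numbers for more inhibition of growth at the one concentration tested. Compound 1 gives 4.35% and compound 2 gives 2.13%; the step of a number 2.2 percentage points lower from compound 1 to compound 2 (within the scatter) lies within the scatter, so the two cannot be ordered. Compound 3 stands highest of the three, and the step of a number 44.2 percentage points higher from compound 1 to compound 3 (beyond the scatter) is large and beyond the scatter.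

Compound 4 `CCc1ccc(SCc2ccc(C(=O)Nc3ccccc3N)cc2)cc1` has not yet been measured. It differs from compound 3 in one place: 4-ethylphenyl in place of 3,5-dimethylphenyl on a sulfur.

Within the data shown here, two measured steps bear on this change. The step of a number 44.2 percentage points higher from compound 1 to compound 3 (beyond the scatter) shows that replacing a 4-bromophenyl on the sulfur with a 3,5-dimethylphenyl raised the number strongly, while the step of a number 2.2 percentage points lower from compound 1 to compound 2 (within the scatter) shows that exchanging one group on the aromatic carbon for another left the number unchanged. Compound 4 carries a 4-ethylphenyl on the sulfur, as compounds 1 and 2 carry groups on the same position of their phenyl ring, and both of those gave low numbers. The step to compound 4 is therefore expected to go downward, by about a number 36.5 percentage points lower from compound 3 to compound 4 (beyond the scatter). Compound 4 is thus estimated at 12%, with a range from 0% to 40%.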

Compound 4, percent growth inhibition at one concentration: 19.6%
Compound 4: the middle estimate sits 7.6 percentage points below what was measured, within the range that was stated.
By their numbers in this assay, from the lowest: compounds 2 and 1 (each within the scatter of the next); then compound 4; then compound 3.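

In this assay, the group on the sulfur proved sensitive to how its carbons are arranged: 4-ethylphenyl and 3,5-dimethylphenyl hold the same atoms, joined differently, yet the exchange gave a clear change (a number 28.9 percentage points lower from compound 3 to compound 4 (beyond the scatter)). The group on the aromatic carbon also made a difference that compounds 1 and 2 alone had not revealed, since ethyl in place of tert-butyl (a number 17.5 percentage points higher from compound 2 to compound 4 (beyond the scatter)) and ethyl in place of bromo (a number 15.3 percentage points higher from compound 1 to compound 4 (beyond the scatter)) each moved the number beyond the scatter. No measurement shown here accounts for these differences.

From the compounds shown here alone, how a 4-methylphenyl, a 4-propylphenyl or a 4-aminophenyl on the sulfur would read remains open. Also open, going by these compounds, is whether two methyl groups are needed for the higher number of compound 3, or whether a single methyl group would serve.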